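Swapping the aryl group on the amide of a weak antiproliferative

The compounds below may be only part of what the source reports. "The series", "measured", "known", "first", "only" and "open" are said of these compounds alone.

Measured so far:
compound 1 `COc1cccc(C(=O)Nc2cc3cnc(NCCN(C)C)cc3n(C)c2=O)c1`: 43300 nM
compound 2 `CN(C)CCNc1cc2c(cn1)cc(NC(=O)c1ccc(N)cc1)c(=O)n2C`: 55800 nM

Both compounds share one core and differ only in the ring attached to the carbonyl carbon of the amide. In a functional assay on MCF7 cells (Homo sapiens) for antiproliferative activity, read by MTT assay, with a stated time of 48 h (a higher number here means a weaker inhibitor, a lower number a stronger inhibitor), compound 1 gives 43300 nM, and compound 2 gives 55800 nM. Compound 2 holds the highest of the two numbers, but its nearest neighbour is compound 1, and the step of a 1.3-fold higher number from compound 1 to compound 2 (0.11 log units; within the scatter) lies within the scatter, so the two cannot be ordered.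

Compound 3 `CN(C)CCNc1cc2c(cn1)cc(NC(=O)c1ccncc1)c(=O)n2C` has not yet been measured. It differs from compound 2 in one place: pyridin-4-yl in place of 4-aminophenyl on a carbonyl carbon. For the measured compounds named here, the only step that bears on this change is the one from compound 1 to compound 2, which also swapped the ring on the carbonyl carbon and produced a 1.3-fold higher number from compound 1 to compound 2 (0.11 log units; within the scatter). That earlier swap moved the number very little, so the expectation for this one is a step of about a 1.1-fold lower number from compound 2 to compound 3 (0.05 log units; within the scatter) in this assay, with no clear direction beyond the scatter. Compound 3 is therefore estimated at 50000 nM, within a range from 20000 nM to 130000 nM.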

Compound 3, half-maximal inhibitory concentration: 36600 nM
Compound 3: the middle estimate sits 1.4-fold (0.14 log units) above what was measured, and the stated range covers the measured number.
By their numbers in this assay, from the lowest: compounds 3, 1 and 2 (each within the scatter of the next).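

With pyridin-4-yl on the carbonyl carbon, a ring with a hetero atom and no hydrogen-bond donor now stands at this position, and in this assay the swap from 4-aminophenyl gives a 1.5-fold lower number from compound 2 to compound 3 (0.18 log units; within the scatter), while the swap from 3-methoxyphenyl gives a 1.2-fold lower number from compound 1 to compound 3 (0.07 log units; within the scatter). For the compounds shown here, the earlier pair showed only that two carbon-only rings could not be told apart, whereas these steps extend that to a ring containing a hetero atom, so none of the three rings on this carbonyl carbon can be ordered against another in this assay. Nothing available accounts for how alike these numbers are.

Going by these compounds, all three groups are six-membered aromatic rings, so it remains open whether a non-aromatic group such as cyclohexyl, a small alkyl group such as methyl, or a ring bearing a carboxylic acid would shift the number beyond the scatter. The dimethylaminoethyl chain on the shared core is also the same in all three compounds, so these results cannot show whether a longer chain there would matter more than the ring on the carbonyl carbon.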